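A few compounds are considered here, and "the series" means these few. Any claim that something is new, unique, unknown or untested is made for them only; others in the source may bear on it.

Measured compounds:
- compound 1 `COc1cc(F)c(NC(=O)c2ccnc(Cl)c2)cc1Nc1nccc(-c2cn(C)c3ccccc23)n1`, 4330 nM in a functional assay on NCI-H1975 cells (Homo sapiens) for antiproliferative activity, read by MTT assay, with a stated time of 72 h; a lower number here means a stronger inhibitor, a higher number a weaker inhibitor
- compound 2 `COc1cc(N(C)CCN(C)C)c(NC(=O)c2ccncc2)cc1Nc1nccc(-c2cn(C)c3ccccc23)n1`, 6860 nM in this assay

Compound 2 has the higher of the two numbers, but its distance from compound 1 lies within the usual scatter, so the two cannot be told apart. Compound 3 `COc1cc(N(C)CCN(C)C)c(NC(=O)c2ccnc(Cl)c2)cc1Nc1nccc(-c2cn(C)c3ccccc23)n1` differs from compound 2 in one place: chloro in place of hydrogen on an aromatic carbon. Going by the values given here, no pair of measured compounds isolates this change, so nothing here shows how large its effect is. The expected step from compound 2 to compound 3 is a 1.2-fold lower number from compound 2 to compound 3 (0.10 log units; within the scatter), not beyond the scatter. Compound 3 is therefore estimated at 5500 nM, with a range from 2000 nM to 14000 nM.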

Compound 3, half-maximal inhibitory concentration: 2050 nM
The estimate for compound 3 lay 2.7-fold (0.43 log units) above the measured number; the range from low to high includes it.
By their numbers in this assay, from the lowest: compound 3; then compounds 1 and 2 (each within the scatter of the next).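

In this assay, chloro in place of hydrogen next to the ring nitrogen gives a 3.3-fold lower number from compound 2 to compound 3 (0.52 log units; beyond the scatter), so a single added atom at this position changes the number beyond the scatter. With 2-chloropyridin-4-yl kept, (2-(dimethylamino)ethyl)(methyl)amino in place of fluoro gives a 2.1-fold lower number from compound 1 to compound 3 (0.32 log units; beyond the scatter), so that second place on the shared core matters too. Nothing available here explains either step.

On these data alone, whether bromo, methyl or an amine on the same carbon would lower the number further remains open. So does whether chloro gives a similar step when fluoro replaces the chain.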